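Swapping Diethylamino for Azepan-1-yl on the Sulfonyl Sulfur

This account rests on a few compounds, and the source may have more. Where it says the series, first, only, none or still open, it means among the compounds named here.

Measured in a functional assay on MCF7 cells (Homo sapiens) for inhibition, with a stated time of 72 h; on this read-out higher numbers stand for weaker inhibition of growth and lower numbers for stronger inhibition of growth:
compound 1 `CCN(CC)S(=O)(=O)c1ccc(OC)c(NC(=O)c2[nH]c(C)c3c2CCCCC3=O)c1`: 6840 nM
compound 2 `CCN(CC)S(=O)(=O)c1ccc(O)c(NC(=O)c2[nH]c(C)c3c2CCCCC3=O)c1`: > 40000 nM

Within the data shown here, compound 1 holds the only true number in this assay, at 6840 nM. Compound 2 gives > 40000 nM, which is a limit of the assay and not a number. Among the measured compounds shown here, the one measured step, an at least 5.8-fold higher number from compound 1 to compound 2 (0.76 log units; beyond the scatter), puts hydrogen in place of methyl on an oxygen on an aromatic ring. That step leaves the sulfonyl sulfur untouched, so its size says little about the change considered here.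

Compound 3 `COc1ccc(S(=O)(=O)N2CCCCCC2)cc1NC(=O)c1[nH]c(C)c2c1CCCCC2=O` keeps the core of compound 1 and carries azepan-1-yl in place of diethylamino on a sulfonyl sulfur. For the measured compounds named here, no measured step covers a change at this place. The expectation therefore rests on compound 1 at 6840 nM, and no step beyond the scatter is expected in this assay, in either direction. The expected step is small, a 1.2-fold lower number from compound 1 to compound 3 (0.09 log units; within the scatter). Compound 3 is estimated at 5500 nM, with an expected range of 2200 nM to 16000 nM.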

Compound 3, concentration for 50% growth inhibition: 3000 nM
Estimate against measurement, compound 3: 1.8-fold (0.26 log units) above, and the stated range covers the measured number.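

Among these compounds, until now the only measured change sat on an oxygen on the aromatic ring, so compound 3 gives the first reading at the sulfonyl sulfur: in this assay, azepan-1-yl in place of diethylamino brings a 2.3-fold lower number from compound 1 to compound 3 (0.36 log units; beyond the scatter). A lower number here means stronger inhibition of growth, so this place on the molecule can be changed without losing activity, and this change gives a modest gain that lies beyond the usual scatter. The swap replaces an open group of 5 heavy atoms with a seven-membered ring of 7 heavy atoms, and nothing shown explains why the number falls or separates the effect of the ring from that of the added atoms.

As far as these compounds go, it remains open whether the ring itself or the larger size of the group matters, a question that piperidin-1-yl, morpholin-4-yl or an open dipropylamino group on the same sulfur could help to answer. From the compounds shown here alone, it is also open whether other groups on that oxygen, such as ethyl, would behave the same way alongside azepan-1-yl as they do alongside diethylamino.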